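Replacing the side group on the triazole of compound 1

A few compounds are considered here, and "the series" means these few. Any claim that something is new, unique, unknown or untested is made for them only; others in the source may bear on it.

In a toxicity assay on L02 cells (Homo sapiens) for cytotoxicity, read by MTT assay, with a stated time of 72 h (on this read-out higher numbers stand for weaker inhibition and lower numbers for stronger inhibition), compound 1 `O=C1c2c[n+]([O-])c3ccccc3c2C(=O)c2c1c1ccccc1n2Cc1cn(CC(O)CO)nn1` gives 1070 nM and compound 2 `O=C1c2c[n+]([O-])c3ccccc3c2C(=O)c2c1c1ccccc1n2CCN1CCCC1` gives 930 nM within the scatter of that value. Compound 3 `O=C1c2c[n+]([O-])c3ccccc3c2C(=O)c2c1c1ccccc1n2Cc1cn([C@@H]2O[C@H](CO)[C@@H](O)[C@H](O)[C@H]2O)nn1`, not yet measured, carries 3,4,5-trihydroxy-6-(hydroxymethyl)oxan-2-yl in place of 2,3-dihydroxypropyl on an aromatic nitrogen and keeps the core of compound 1. Among the compounds with values here, the only measured step of a 1.2-fold lower number from compound 1 to compound 2 (0.06 log units; within the scatter) stays within the scatter, although it replaces the whole 1-(2,3-dihydroxypropyl)-1H-1,2,3-triazol-4-yl group. The expected step of a 1.1-fold higher number from compound 1 to compound 3 (0.05 log units; within the scatter) in this assay is therefore none beyond the scatter. Compound 3 is estimated at 1200 nM with 450 nM to 3200 nM as its expected range.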

Compound 3, half-maximal inhibitory concentration: 420 nM
For compound 3 the middle estimate is 2.9-fold (0.46 log units) above the measured one; measured number below the stated range.
By their numbers in this assay, from the lowest: compound 3; then compounds 2 and 1 (each within the scatter of the next).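

In this assay, the group on an aromatic nitrogen of the five-membered aromatic ring with 3 nitrogen does affect the read-out: 3,4,5-trihydroxy-6-(hydroxymethyl)oxan-2-yl in place of 2,3-dihydroxypropyl gives a 2.5-fold lower number from compound 1 to compound 3 (0.41 log units; beyond the scatter), the only step shown beyond the scatter. This change adds a six-membered non-aromatic ring and 5 defined stereocentres together, so the compounds cannot separate their contributions. Nothing measured here accounts for the step. The compounds shown leave open how a carboxylic acid or a plain methyl group at this nitrogen would read. They also leave open whether the stereocentres of the entering group affect the number.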